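The compounds below may be only part of what the source reports. "The series", "measured", "known", "first", "only" and "open" are said of these compounds alone.

Compound 1 `CNC(=O)c1cc(Oc2ccc3oc(Nc4cccc(C(C)C)c4)nc3c2)ccn1` gives 10 10^-6 cm/s in an ADME assay on Caco-2 cells (Homo sapiens) for permeability, in the apical to basolateral direction; a higher number here means that the compound crosses the layer faster, a lower number that the compound crosses the layer more slowly.
Compound 2 `CCc1ccc(Nc2nc3cc(Oc4ccnc(C(=O)NC)c4)ccc3o2)cc1` gives 10 10^-6 cm/s in this assay.

For the measured compounds named here, compound 2 stands level with compound 1 on this read-out: the single measured step, no change at the digits printed from compound 1 to compound 2 (within the scatter), stays within the scatter, so exchanging one alkyl-bearing phenyl for another left the crossing rate where it was. Compound 3 `CNC(=O)c1cc(Oc2ccc3oc(Nc4ccc(N(C)C)cc4)nc3c2)ccn1` has not yet been measured. It differs from compound 2 in one place: dimethylamino in place of ethyl on an aromatic carbon. Going by the values given here, the only step on record alters the same phenyl ring, but trades one alkyl group for another, whereas here a group carrying one hydrogen-bond acceptor enters. That earlier step is still the closest guide, and it showed no movement. Among the compounds with values here, no measured compound here carries an acceptor at that spot, so the expectation leans on the flat step from compound 1 to compound 2 and allows only a modest drift downward. Compound 3 is therefore expected to sit close to compound 2, with the expected step of a 1.3-fold lower number from compound 2 to compound 3 (0.10 log units; within the scatter) lying within the usual scatter. The estimate for compound 3 in this assay is 8 10^-6 cm/s, within a range from 4 10^-6 cm/s to 16 10^-6 cm/s.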

Compound 3, apparent permeability: 10 10^-6 cm/s
Beside the measured number, compound 3's estimate is 1.3-fold (0.10 log units) below it; measured number inside the range.
By their numbers in this assay, from the lowest: compounds 1, 2 and 3 (each within the scatter of the next).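

For the compounds shown here, until now, the only step on this phenyl ring had exchanged one alkyl group for another, whereas dimethylamino in place of ethyl, on an aromatic carbon para to a large group, brings in a nitrogen and a hydrogen-bond acceptor, and this assay still reads no change at the digits printed from compound 2 to compound 3 (within the scatter). The wider exchange of 3-isopropylphenyl for 4-(dimethylamino)phenyl, which alters both the group and where it sits on the ring, gives no change at the digits printed from compound 1 to compound 3 (within the scatter), so all three compounds stand level on this read-out. This position has therefore now accepted a group with a hydrogen-bond acceptor as well as plain alkyl groups with the number staying level, though no measurement here accounts for that result.

These compounds leave open whether the number would stay level with a primary amine or a hydroxyl group on the same carbon, since neither the ethyl nor the dimethylamino group has a hydrogen-bond donor. A carboxylic acid or a longer chain at this spot also remains an open question, so how far this level reading extends is not yet known.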